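The source may hold more compounds than are shown below. What is called first, only, known or untested is meant among the compounds shown, and "the series" means these compounds.

Compound 1 `COc1ncnc2c1c(-c1cccs1)cn2[C@@H]1O[C@H](CO)[C@@H](O)[C@H]1O` and compound 2 `Cc1ncnc2c1c(-c1cccs1)cn2[C@@H]1O[C@H](CO)[C@@H](O)[C@H]1O` share one core and differ at a single aromatic carbon, where compound 1 carries a methoxy and compound 2 a methyl. In a functional assay on K562 cells (Homo sapiens), read by MTT assay, with a stated time of 72 h (a higher number here means a weaker inhibitor, a lower number a stronger inhibitor), compound 1 gives 70 nM. Compound 2 reaches only the limit of this assay, recorded as > 20000 nM, so its true number is not known. The swap gave an at least 280-fold higher number from compound 1 to compound 2 (2.45 log units; beyond the scatter), and this step is itself only a floor because compound 2 sits at the limit of > 20000 nM in this assay, at which 1 of the 2 values shown sits. Compound 2 therefore stands at the weak end of the numbers shown, with compound 1 the far stronger of the two. Compound 3 `CSc1ncnc2c1c(-c1cccs1)cn2[C@@H]1O[C@H](CO)[C@@H](O)[C@H]1O` makes the next change: methylsulfanyl in place of methyl on an aromatic carbon. For the measured compounds named here, only the step from compound 1 to compound 2 bears on it, and there the group with a hydrogen-bond acceptor went with a strong number while the bare methyl went with none at all. Since methylsulfanyl brings a hydrogen-bond acceptor back, a large drop in the number of this assay is expected, as an at least 50-fold lower number from compound 2 to compound 3 (1.69 log units; beyond the scatter). Compound 3 is thus expected to give 400 nM, in the range 40 nM to 8000 nM.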

Compound 3, half-maximal inhibitory concentration: 11600 nM
Estimate against measurement, compound 3: 29-fold (1.46 log units) below; measured number outside the range, above it.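

Putting methylsulfanyl in place of methoxy on this aromatic carbon gives a 170-fold higher number from compound 1 to compound 3 (2.22 log units; beyond the scatter), so among these compounds a hydrogen-bond acceptor in the group is not enough on its own to keep the strong number seen with methoxy. Set against the methyl, the same group gives an at least 1.7-fold lower number from compound 2 to compound 3 (0.23 log units; that floor lies within the scatter), and because that floor lies within the scatter, these numbers show no clear gain for methylsulfanyl over methyl, although a larger true gain is not ruled out. The step stays a floor because compound 2 is recorded only as a limit and not as a number: the limit of > 20000 nM in this assay, at which 1 of the 3 values shown sits.

The compounds shown leave open whether the strong number belongs to methoxy alone or would also appear with ethoxy, a slightly longer oxygen-linked chain, or with an amine on the same carbon. As far as these compounds go, they also leave open how far the true number of compound 2 lies from that of compound 3, so the real size of the change from methyl to methylsulfanyl remains unknown.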